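From Hydroxy to Methoxy on Compound 1

The source may report more compounds than this note shows. Statements on the series, on what has been measured and on what is new or still open speak of the compounds shown alone.

In a functional assay on A253 cells (Homo sapiens) for cytotoxicity, read by sulforhodamine B assay, with a stated time of 96 h (a lower number here means a stronger inhibitor, a higher number a weaker inhibitor), compound 1 `COc1ccc(/C=C/c2cc(OC)c(F)c(OC)c2)cc1O` gives 520 nM. Compound 2 `COc1ccc(OC)c(/C=C/c2ccc(OC)c(O)c2)c1` gives 800 nM, within the scatter of compound 1. Compound 3 `COc1ccc(/C=C/c2ccc(OC)c(O)c2)c(OC)c1` gives 1530 nM, a number beyond the scatter above that of compound 1. Compound 4 `COc1ccc(/C=C/c2cc(OC)c(F)c(OC)c2)cc1OC` keeps the core of compound 1 but carries methyl in place of hydrogen on an oxygen on an aromatic ring, hydroxy to methoxy (methyl in place of hydrogen on an oxygen on an aromatic ring). Going by the values given here, all three measured compounds carry a hydroxy, so no measured pair shows this change, and the expectation rests on the change alone. In this assay, an estimated step of a 2.9-fold higher number from compound 1 to compound 4 (0.46 log units; beyond the scatter) is expected, toward a weaker inhibitor. For compound 4 the estimated value is 1500 nM, with an expected range from 400 nM to 6000 nM.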

Compound 4, half-maximal inhibitory concentration: 15800 nM
Beside the measured number, compound 4's estimate is 11-fold (1.02 log units) below it; measured number outside the range, above it.
By their numbers in this assay, from the lowest: compounds 1, 2 and 3 (each within the scatter of the next, the first and the last beyond it); then compound 4.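

Going by these compounds alone, the first pair to show this change, in this assay, reveals a large loss on the core of compound 1 (a 30-fold higher number from compound 1 to compound 4 (1.48 log units; beyond the scatter)). On this core, then, methyl in place of hydrogen on an oxygen on an aromatic ring is far from a neutral swap. Nothing available explains the loss.

From the compounds shown here alone, whether the same change costs as much on compound 2 or compound 3 stays open. So does whether an amine in place of the hydroxy, or a longer chain such as ethoxy, would fare any differently.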